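Methoxymethoxy for Methoxy: Cytotoxicity Expected to Stay Weak

A few compounds are considered here, and "the series" means these few. Any claim that something is new, unique, unknown or untested is made for them only; others in the source may bear on it.

Compound 1, `COc1ccc(C2=C(c3cc(OC)c(OC)c(OC)c3)C(=O)C(OC(C)=O)C2)cc1F`, gives 59 ug/mL in an ADME assay on HEK293 cells (Homo sapiens) for cytotoxicity, read by MTT assay, with a stated time of 72 h; on this read-out lower numbers stand for stronger inhibition and higher numbers for weaker inhibition.
Compound 2, `COc1ccc(C2=C(c3cc(OC)c(OC)c(OC)c3)C(=O)CC2O[SiH2]C(C)(C)C)cc1OC`, reaches only the limit of this assay, > 100 ug/mL.
Compound 3, `COc1ccc(C2=C(c3cc(OC)c(OC)c(OC)c3)CC(O)C2=O)cc1[N+](=O)[O-]`, likewise reaches only the limit, > 100 ug/mL.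

Compound 2 therefore has no number of its own in this assay; it sits at the limit of > 100 ug/mL in this assay, at which 2 of the 3 values shown sit, so its cytotoxicity is weak and only bounded. Compound 4, `COCOc1cc(C2=C(c3cc(OC)c(OC)c(OC)c3)C(=O)CC2O[SiH2]C(C)(C)C)ccc1OC`, is the unmeasured partner. The change from compound 2 is methoxy in place of hydrogen on a saturated chain carbon bound to an oxygen on an aromatic ring. Going by the values given here, no measured pair shows such a change, so the expected step is small: a step that the limit leaves unreadable from compound 2 to compound 4 is estimated as none beyond the usual scatter, most likely ending at the limit again. Compound 4 is expected near 120 ug/mL, within 50 ug/mL to 300 ug/mL.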

Compound 4, half-maximal inhibitory concentration: > 100 ug/mL
Compound 4: no number, only a limit; the forecaster's own chance of this, stated with the estimate: 65%; the middle value is on the limit's open side.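

Compound 2 and compound 4 each give only a limit, not a number, so no step between them can be read in this assay: the limit of > 100 ug/mL in this assay, at which 3 of the 4 values shown sit.

As far as these compounds go, whether changing methoxy to methoxymethoxy alters cytotoxicity at all remains open.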